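Aryl ether series: cytotoxicity outlook for a difluorophenyl analogue

The compounds below may be only part of what the source reports. "The series", "measured", "known", "first", "only" and "open" are said of these compounds alone.

Compound 1 `CCOC(=O)c1cc(-c2cccc(OCc3ccccc3F)c2)on1` has no result in an ADME assay on Vero cells (Chlorocebus sabaeus) for cytotoxicity, with a stated time of 72 h (a lower number here means a stronger inhibitor, a higher number a weaker inhibitor), and is recorded as "not determined" (no result reported). Compound 2 `CCOC(=O)c1cc(-c2cccc(OCc3ccccc3[N+](=O)[O-])c2)on1` reaches only a limit of this assay, > 128000 nM. Its standing is thus set by the limit of > 128000 nM in this assay, at which 1 of the 2 values shown sits, with no single number for the series. Compound 3 `CCOC(=O)c1cc(-c2cccc(OCc3c(F)cccc3F)c2)on1` differs by 2,6-difluorophenyl in place of 2-nitrophenyl on a saturated chain carbon bound to an oxygen on an aromatic ring. Within the data shown here, no measured step between compounds exists here, so the expected step that the limit leaves unreadable from compound 2 to compound 3 is none beyond the scatter. Compound 3 is expected to give 150000 nM, within a range from 60000 nM to 400000 nM, most likely again reported as a limit in this assay.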

Compound 3, half-maximal inhibitory concentration: > 128000 nM
Compound 3: only a limit was reported; the forecaster's own chance of this, stated with the estimate: 75%; the middle value does not contradict the limit.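

Among these compounds, no step from compound 2 to compound 3 can be read in this assay, since both results are limits: the limit of > 128000 nM in this assay, at which 2 of the 3 values shown sit. The compounds shown leave open whether any group at this place gives a single number in this assay.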